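The source may report more compounds than this note shows. Statements on the series, on what has been measured and on what is new or still open speak of the compounds shown alone.

Compound 1 `CN(C)CCn1cnnc1-c1cc(Oc2ccc(NC(=O)N/N=C/c3ccc(Cl)cc3)cc2F)ccn1` gives the lowest number of the three measured in a functional assay on HT-29 cells (Homo sapiens) for cytotoxicity, read by MTT assay, with a stated time of 72 h (on this read-out higher numbers stand for weaker inhibition and lower numbers for stronger inhibition), with a value of 530 nM. Compound 2 `CN(C)CCn1cnnc1-c1cc(Oc2ccc(NC(=O)N/N=C/c3ccc(O)c(O)c3)cc2F)ccn1` gives 1890 nM in this assay, and compound 3 `COc1ccc(/C=N/NC(=O)Nc2ccc(Oc3ccnc(-c4nncn4CCN(C)C)c3)c(F)c2)c(OC)c1` gives 1780 nM. Compound 4 `COc1cc(/C=N/NC(=O)Nc2ccc(Oc3ccnc(-c4nncn4CCN(C)C)c3)c(F)c2)cc(OC)c1OC` differs from compound 1 in one place: 3,4,5-trimethoxyphenyl in place of 4-chlorophenyl on a carbon with a double bond to nitrogen. For the measured compounds named here, two measured steps bear on this change, each replacing the same group with an oxygen-bearing aryl group: a 3.6-fold higher number from compound 1 to compound 2 (0.55 log units; beyond the scatter) and a 3.4-fold higher number from compound 1 to compound 3 (0.53 log units; beyond the scatter), while a 1.1-fold lower number from compound 2 to compound 3 (0.03 log units; within the scatter). On that basis a modest rise in the number is expected for compound 4, beyond the scatter, so that the step is estimated at a 3.4-fold higher number from compound 1 to compound 4 (0.53 log units; beyond the scatter). Compound 4 is therefore expected to give about 1800 nM in this assay, within a range of 700 nM to 4500 nM.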

Compound 4, half-maximal inhibitory concentration: 3620 nM
Compound 4: middle estimate off by 2.0-fold (0.30 log units), on the low side, within the range that was stated.
By their numbers in this assay, from the lowest: compound 1; then compounds 3, 2 and 4 (each within the scatter of the next, the first and the last beyond it).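

With a third oxygen-bearing aryl group on the carbon with a double bond to nitrogen, this assay again shows a rise from the 4-chlorophenyl compound, with a 6.8-fold higher number from compound 1 to compound 4 (0.83 log units; beyond the scatter), leaving compound 1 the strongest of the four. The oxygen-bearing groups also no longer sit together: the data show a 2.0-fold higher number from compound 3 to compound 4 (0.31 log units; beyond the scatter), but also a 1.9-fold higher number from compound 2 to compound 4 (0.28 log units; within the scatter). No measurement at hand accounts for these differences.

The compounds shown leave open whether the rise follows from the oxygen-bearing groups or from the loss of chlorine. They also leave open how an unsubstituted phenyl ring, or a ring carrying an amine or a carboxylic acid, would read here.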